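Swapping a Cyanophenyl for a Hydroxyphenyl on the Shared Core

The source may hold more compounds than are shown below. What is called first, only, known or untested is meant among the compounds shown, and "the series" means these compounds.

Compound 1 `CCc1ccc(-c2nc3c(c(C)nn3-c3ccccc3)c(-c3ccccc3C#N)c2C#N)cc1` was tested in an ADME assay on BJ cells (Homo sapiens) for cytotoxicity, with a stated time of 72 h; on this read-out higher numbers stand for an effect only at larger amounts of compound and lower numbers for an effect already at smaller amounts. In this assay compound 1 gives > 20000 nM, which is a limit of the measurement rather than a number. For the measured compounds named here, compound 2 `CCc1ccc(-c2nc3c(c(C)nn3-c3ccccc3)c(-c3ccccc3Br)c2C#N)cc1` is the only other compound measured alongside it. In this assay compound 2 gives > 20000 nM, again a limit. The step that the two limits leave unreadable from compound 1 to compound 2 therefore cannot be read. Both measurements fall on (the limit of > 20000 nM in this assay, at which 2 of the 2 values shown sit), so compound 1 stands at the edge of what this assay reports, with no number that would place it more finely.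

Compound 3 `CCc1ccc(-c2nc3c(c(C)nn3-c3ccccc3)c(-c3cccc(O)c3)c2C#N)cc1` has not yet been measured in this assay. It differs from compound 1 as follows: 3-hydroxyphenyl in place of 2-cyanophenyl on an aromatic carbon. Going by the values given here, no measured step bears directly on this exchange, and the one step on hand was itself unreadable. The expectation is that compound 3 stays at the limit, so the estimated step that the limit leaves unreadable from compound 1 to compound 3 is none beyond the scatter. Compound 3 is therefore estimated at 25000 nM, with a range from 8000 nM to 80000 nM.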

Compound 3, half-maximal effective concentration: > 20000 nM
Compound 3: only a limit was reported (the forecaster's own chance of this, stated with the estimate: 70%); the middle value is on the limit's open side.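

In this assay compound 3 gives > 20000 nM, which is a limit and not a number. Its steps from compound 1 and from compound 2 therefore cannot be read, and all three compounds sit at the same limit: the limit of > 20000 nM in this assay, at which 3 of the 3 values shown sit. The compounds shown leave open at what concentration, if any, compound 1, compound 2 or compound 3 would affect these cells.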